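Methyl ester in place of methoxyazetidine amide

The source may hold more compounds than are shown below. What is called first, only, known or untested is meant among the compounds shown, and "the series" means these compounds.

Working notes on the series. Among the measured compounds shown here, compound 2 `COC1CN(C(=O)/C=C/c2ccncc2-c2ccc3ccccc3c2)C1` is the only member with a number in hand: in an assay on a protein complex for inhibition of CDK8/Cyclin C (Homo sapiens), with a stated time of 1 h (a higher number here means a weaker inhibitor, a lower number a stronger inhibitor), compound 2 gives 42.8 nM. For the measured compounds named here, compound 1 `O=C(O)[C@@H]1CCCN1C(=O)/C=C/c1ccncc1-c1ccc2ccccc2c1` belongs to the same series, but in this assay compound 1 gives "not determined" (no result reported), so compound 2 stands alone and no step between two measured compounds can be written down.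

Compound 3 `COC(=O)/C=C/c1ccncc1-c1ccc2ccccc2c1` differs from compound 2 by methoxy in place of 3-methoxyazetidin-1-yl on a carbonyl carbon. Going by the values given here, no measured step of this kind exists, so the expectation rests on compound 2 alone and on the nature of the change. The step of a 3.5-fold higher number from compound 2 to compound 3 (0.54 log units; beyond the scatter) is expected to be a loss of some size, beyond the usual scatter but not large. For compound 3 the result expected in this assay is 150 nM, with a range from 45 nM to 600 nM.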

Compound 3, half-maximal inhibitory concentration: 40.6 nM
For compound 3 the middle estimate is 3.7-fold (0.57 log units) above the measured one, outside the stated range (below it).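

In this assay, methoxy in place of 3-methoxyazetidin-1-yl on a carbonyl carbon gives a 1.1-fold lower number from compound 2 to compound 3 (0.02 log units; within the scatter) and leaves the two compounds indistinguishable. For this pair, the four-membered non-aromatic ring and the larger group that carries it can leave the carbonyl carbon without any change in the read-out, so the amide of compound 2 and the methyl ester of compound 3 stand level on the shared core. No measurement in hand offers an explanation for this result.

Among the compounds shown here, compound 1 gives "not determined" (no result reported) and so offers no step that can be read. Going by these compounds, whether the same level holds with a hydroxy group, forming a free carboxylic acid, or with dimethylamino on this carbonyl carbon remains open, as does the reach of this result beyond this pair.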